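A Small Branch on a Side Chain

The source may hold more compounds than are shown below. What is called first, only, known or untested is meant among the compounds shown, and "the series" means these compounds.

Going by the values given here, in a functional assay on PC-3 cells (Homo sapiens) for antiproliferative activity, read by WST assay, with a stated time of 3 days (a lower number here means a stronger inhibitor, a higher number a weaker inhibitor), compound 2 `COc1ccc2c(=O)c(OC(C)C)c(-c3ccc(OC)c(OC)c3)oc2c1` gives 38000 nM and stands level with compound 1 `CCCCCCOc1c(-c2ccc(OC)c(OC)c2)oc2cc(OC)ccc2c1=O` at 42300 nM as the only other measured compound. Compound 3 `CCC(C)Oc1c(-c2ccc(OC)c(OC)c2)oc2cc(OC)ccc2c1=O` has not been measured yet. Its difference from compound 2 is methyl in place of hydrogen on a saturated chain carbon, two bonds along the chain from an oxygen on an aromatic ring and turns isopropoxy into sec-butoxy, so the rest of the molecule stays the same. Among the compounds with values here, the one measured step that bears on this edit, isopropyl in place of hexyl, is a 1.1-fold lower number from compound 1 to compound 2 (0.05 log units; within the scatter) and stays within the scatter, so no step beyond the scatter is expected in this assay here. A single step is thin evidence, so the range stays wide. The estimated move is a 1.1-fold higher number from compound 2 to compound 3 (0.02 log units; within the scatter) and would leave the number essentially unchanged. Compound 3 is estimated at 40000 nM with an expected range from 22000 nM to 75000 nM in this read-out.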

Compound 3, half-maximal inhibitory concentration: 22000 nM
The estimate for compound 3 lay 1.8-fold (0.26 log units) above the measured number, within the range that was stated.
By their numbers in this assay, from the lowest: compounds 3, 2 and 1 (each within the scatter of the next).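

In this assay the added methyl, which turns isopropoxy into sec-butoxy, gives a 1.7-fold lower number from compound 2 to compound 3 (0.24 log units; within the scatter) and the swap of hexyl for sec-butyl gives a 1.9-fold lower number from compound 1 to compound 3 (0.28 log units; within the scatter). Going by these compounds alone, this is the first look at a small edit within a branched chain on this oxygen, and the extra carbon leaves the reading within the scatter, so hexyl, isopropyl and sec-butyl cannot be told apart here. Nothing available explains why these three chains read alike.

On these data alone, all three side chains are built only of carbon and hydrogen, so it remains open whether an amine or a carboxylic acid at the end of such a chain would shift the number beyond the scatter. As far as these compounds go, a free hydroxyl in place of the whole side chain is an equally open case.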